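Chloro analogue of compound 1 in the cytotoxicity test

The compounds below may be only part of what the source reports. "The series", "measured", "known", "first", "only" and "open" are said of these compounds alone.

Compound 1 `O[C@@H]1Cc2ccccc2N[C@H](c2ccccc2)C1` is the parent of this short series. In an ADME assay on THP-1 cells (Homo sapiens) for cytotoxicity, read by MTT assay, with a stated time of 72 h (on this read-out higher numbers stand for lower toxicity in this test and lower numbers for higher toxicity in this test), compound 1 gives > 300000 nM, which is a limit of the assay rather than a number. Compound 2 `O[C@@H]1Cc2ccccc2N[C@H](c2ccc(F)cc2)C1` carries fluoro in place of hydrogen on an aromatic carbon. In this assay compound 2 gives > 300000 nM, again a limit. The step that the two limits leave unreadable from compound 1 to compound 2 therefore has no readable size, since both ends sit at the limit of > 300000 nM in this assay, at which 2 of the 2 values shown sit. Compound 3 `O[C@@H]1Cc2ccccc2N[C@H](c2ccccc2Cl)C1` is the next member, differing from compound 1 by chloro in place of hydrogen on an aromatic carbon. Among the measured compounds shown here, the only measured step that bears on it, the aromatic halogen substitution leading to compound 2, gave no readable size, and for a chloro group in this position no step is known at all. On the numbers shown, the expectation for this assay is no step beyond the scatter and, most probably, a further limit. Compound 3 is thus expected to show a step that the limit leaves unreadable from compound 1 to compound 3. For compound 3 the estimated value is 400000 nM, within 150000 nM to 1000000 nM.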

Compound 3, half-maximal cytotoxic concentration: > 300000 nM
Compound 3: a limit, no number; the forecaster's own chance of this, stated with the estimate: 85%; the middle value lies beyond the limit too.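

In this assay compound 3 gives > 300000 nM, which is a limit and not a number. Among the compounds shown here, no step from compound 1 to compound 2 or to compound 3 can be read, since all the values sit at one limit: the limit of > 300000 nM in this assay, at which 3 of the 3 values shown sit. The compounds shown leave open whether compound 2 and compound 3 differ from compound 1 at all in this assay.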